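The compounds below may be only part of what the source reports. "The series", "measured", "known", "first", "only" and "open" are said of these compounds alone.

Measured in a functional assay on A549 cells (Homo sapiens) for cytotoxicity, read by MTT assay, with a stated time of 48 h (on this read-out lower numbers stand for stronger inhibition and higher numbers for weaker inhibition), so far:
- Compound 1 `COc1cc([C@H]2C[C@@]2(CO)C(=O)Nc2ccccc2)cc(OC)c1OC` gives > 100000 nM (a limit)
- Compound 2 `COc1cc([C@H]2C[C@]2(CO)C(=O)NCc2ccc(C)cc2)cc(OC)c1OC` gives 60700 nM (a number)
- Compound 3 `CCOC(=O)[C@@]1(C(=O)NCc2ccc(C)cc2)C[C@@H]1c1cc(OC)c(OC)c(OC)c1` gives > 100000 nM (a limit)

Compound 3 has only a limit and no number. It stands at the limit of > 100000 nM in this assay, at which 2 of the 3 values shown sit, and shares that position with compound 1.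

Compound 4 `COc1cc([C@H]2C[C@@]2(CO)C(=O)NCc2ccc(C)cc2)cc(OC)c1OC` carries hydroxymethyl in place of the ethoxycarbonyl of compound 3, on a saturated ring carbon (the count: hydroxymethyl in place of ethoxycarbonyl on a saturated ring carbon).

In this assay a modest step toward stronger inhibition is expected, although it may not clear the limit. For the measured compounds named here, the one number available belongs to compound 2 at 60700 nM and this compound carries hydroxymethyl, which gives the expectation its direction. Compound 1 goes against that reading, since it also carries hydroxymethyl and gives only the limit > 100000 nM here.

The estimated step is an at least 1.4-fold lower number from compound 3 to compound 4 (0.15 log units; that floor lies within the scatter) and it remains uncertain, as it starts from a limit.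

For compound 4 the expected value is 70000 nM (estimated range 30000 nM to 120000 nM).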

Compound 4, half-maximal inhibitory concentration: 63800 nM
Estimate against measurement, compound 4: 1.1-fold (0.04 log units) above; the range from low to high includes it.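

In this assay, hydroxymethyl in place of ethoxycarbonyl on this saturated ring carbon gives an at least 1.5-fold lower number from compound 3 to compound 4 (0.19 log units; that floor lies within the scatter) and yields a number where compound 3 has only a limit. The configuration drawn at this carbon has no readable effect, since the step is a 1.1-fold higher number from compound 2 to compound 4 (0.02 log units; within the scatter) for a pair that differs in nothing else: the fact that compounds 2 and 4 differ only in the configuration as drawn. With hydroxymethyl kept, 4-methylbenzyl in place of phenyl on an amide-type nitrogen gives an at least 1.5-fold lower number from compound 1 to compound 4 (0.19 log units; that floor lies within the scatter) and likewise starts from a limit, that of compound 1: the limit of > 100000 nM in this assay, at which 2 of the 4 values shown sit.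

As far as these compounds go, the true size of both steps that start from a limit stays open, as does whether any group on this carbon can move the number beyond the scatter. From the compounds shown here alone, whether an aminomethyl group or a carboxylic acid there would behave like hydroxymethyl or like ethoxycarbonyl also remains unknown.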